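Side-chain variation on a bisindolylmaleimide amide series

The source may report more compounds than this note shows. Statements on the series, on what has been measured and on what is new or still open speak of the compounds shown alone.

Measured compounds:
compound 1 `COC(=O)CCNC(=O)Cn1cc(C2=C(c3c[nH]c4ccccc34)C(=O)N(C)C2=O)c2ccccc21`, 44500 nM
compound 2 `COC(=O)[C@@H](CO)NC(=O)Cn1cc(C2=C(c3c[nH]c4ccccc34)C(=O)N(C)C2=O)c2ccccc21`, 23200 nM

In a functional assay on A2780 cells (Homo sapiens) for cytotoxicity, read by MTT assay, with a stated time of 24 h (on this read-out lower numbers stand for stronger inhibition and higher numbers for weaker inhibition), compound 1 gives 44500 nM and compound 2 gives 23200 nM. Among the measured compounds shown here, compound 2 holds the lowest of the two numbers, but its only neighbour is compound 1 at a 1.9-fold lower number from compound 1 to compound 2 (0.28 log units; within the scatter), so the two cannot be ordered. Compound 3 `COC(=O)[C@@H](CC(C)C)NC(=O)Cn1cc(C2=C(c3c[nH]c4ccccc34)C(=O)N(C)C2=O)c2ccccc21` carries isopropyl in place of hydroxy on a saturated chain carbon, two bonds along the chain from an amide-type nitrogen and a carbonyl carbon. For the measured compounds named here, the one measured step touches the same chain and stayed within the scatter, so in this assay no step beyond the scatter is expected for compound 3 in either direction. The estimated step is a 1.1-fold higher number from compound 2 to compound 3 (0.03 log units; within the scatter). Compound 3 is expected near 25000 nM, within 8000 nM to 75000 nM.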

Compound 3, half-maximal inhibitory concentration: 38500 nM
Estimate against measurement, compound 3: 1.5-fold (0.19 log units) below, and the stated range covers the measured number.
By their numbers in this assay, from the lowest: compounds 2, 3 and 1 (each within the scatter of the next).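

In this assay isopropyl in place of hydroxy on the saturated chain carbon gives a 1.7-fold higher number from compound 2 to compound 3 (0.22 log units; within the scatter) and 1-(methoxycarbonyl)-3-methylbutyl in place of 2-(methoxycarbonyl)ethyl on the amide-type nitrogen gives a 1.2-fold lower number from compound 1 to compound 3 (0.06 log units; within the scatter) as well. Both steps lie within the scatter, so this position has so far tolerated hydroxymethyl and isobutyl without a readable difference, and compound 3 cannot be ordered against compound 1 or compound 2.

Still open, as far as these compounds go, is whether a carboxylic acid in place of the methyl ester, or an amine on the side chain, would move the number beyond the scatter. No supporting data bear on these results.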